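Replacing the Cyanophenyl on Compound 3 with Pyridinylmethyl

The source may hold more compounds than are shown below. What is called first, only, known or untested is meant among the compounds shown, and "the series" means these compounds.

Compound 3 `N#Cc1ccc(N2CCN(C(=S)SCc3ccc(C(=O)Nc4ccccc4N)cc3)CC2)cc1` gives 41.4% in a functional assay on A-375 cells (Homo sapiens) for antiproliferative activity, read by CCK-8 assay, with a stated time of 72 h, tested at 2 uM (a higher number here means a stronger effect of the compound at the concentration tested, a lower number a weaker effect), the highest of the three measured numbers. Compound 2 `Nc1ccccc1NC(=O)c1ccc(CSC(=S)N2CCc3cc(Cl)ccc32)cc1` gives 31.9%, a number within the usual scatter of compound 3, so no order between the two can be claimed. Compound 1 `Nc1ccccc1NC(=O)c1ccc(CSC(=S)N2CCN(c3ccc(F)cc3)CC2)cc1` gives 20.9%, which lies beyond the scatter below compound 3. Going by the values given here, the only single-point step among the measured compounds is a number 20.5 percentage points higher from compound 1 to compound 3 (beyond the scatter), and it concerns the substituent on the aromatic ring attached to the piperazine nitrogen.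

Compound 4 `Nc1ccccc1NC(=O)c1ccc(CSC(=S)N2CCN(Cc3cccnc3)CC2)cc1` differs from compound 3 in one place: (pyridin-3-yl)methyl in place of 4-cyanophenyl on an amine nitrogen in a ring. Among the compounds with values here, no measured step covers this kind of exchange. Compound 2 carries a different ring system in place of the piperazine and offers no direct guidance, and the pair of compound 1 and compound 3 only shows what a nitrile on that aromatic ring does relative to a fluorine. Since the one improvement seen accompanied the nitrile that compound 4 no longer carries, the account expects compound 4 to lose part of that gain, although with wide uncertainty. Compound 4 is estimated to give 25%, within a range from 10% to 40%. The expected step is a number 16.4 percentage points lower from compound 3 to compound 4 (beyond the scatter).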

Compound 4, a percentage reported as inhibition, at one concentration (the size of the read-out at that concentration, not a potency): 31.5%
For compound 4 the middle estimate is 6.5 percentage points below the measured one; measured number inside the range.
By their numbers in this assay, from the lowest: compound 1; then compounds 4, 2 and 3 (each within the scatter of the next).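

In this assay, the exchange on the amine nitrogen in the ring gives a number 9.9 percentage points lower from compound 3 to compound 4 (within the scatter), so compound 4 holds a number within the scatter of compound 3 without the nitrile. Set against the fluorinated analogue, the same kind of exchange gives a number 10.6 percentage points higher from compound 1 to compound 4 (beyond the scatter), which shows that a nitrile is not the only change at this place that goes with a number beyond the scatter of compound 1, and that the aromatic ring need not sit directly on the amine nitrogen. Nothing on hand explains either step.

The compounds shown leave open whether the step from compound 1 goes with the ring nitrogen of the pyridine or with the methyl link, as the two enter together in compound 4, and a benzyl group on the same amine nitrogen would separate them. Also open, going by these compounds, is how a longer chain, such as pyridinylethyl, would stand at this place, and whether any group here can reach a number beyond the scatter of compound 3.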